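The compounds below may be only part of what the source reports. "The series", "measured", "known", "first", "only" and "open" are said of these compounds alone.

Measured in a physicochemical assay for lipophilicity, read by HPLC, measured as octanol-water partition; on this read-out higher numbers stand for higher lipophilicity and lower numbers for lower lipophilicity:

- Compound 1, `COc1ccc(-c2c(C#N)[n+]([O-])c3cc(C4OCCO4)ccc3[n+]2[O-])cc1`: 1.4
- Compound 2, `O=C(N/N=C/c1ccc2no[n+]([O-])c2c1)c1ccccc1O`: 1.3

Compound 2 gives 1.3 and compound 1 gives 1.4. Within the data shown here, these two values lie within the usual scatter of each other, so compound 2 stands level with the only other number available.

Compound 3, `O=C(N/N=C/c1ccc2no[n+]([O-])c2c1)c1ccc(O)cc1`, has not yet been measured. It carries the same atoms as compound 2, joined differently, with 4-hydroxyphenyl in place of 2-hydroxyphenyl on a carbonyl carbon.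

Among the measured compounds shown here, no measured pair here differs in one place, so the data offer no direct gauge for a step of this kind. A small downward move is expected, a number 0.20 log units lower from compound 2 to compound 3 (within the scatter), and it may not clear the scatter. In this assay the estimated value for compound 3 is 1.1, with an expected range of 0.7 to 1.5.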

Compound 3, partition coefficient: 1.2
Beside the measured number, compound 3's estimate is 0.10 log units below it; the measured number falls inside the stated range.
By their numbers in this assay, from the lowest: compounds 3, 2 and 1 (each within the scatter of the next).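

Placing 4-hydroxyphenyl in place of 2-hydroxyphenyl on a carbonyl carbon gives the first comparison here that differs in one place, and in this assay the step is a number 0.10 log units lower from compound 2 to compound 3 (within the scatter). At this position, then, the two hydroxyphenyl groups, built from the same atoms and joined differently, cannot be told apart on this read-out, and compound 2 and compound 3 stand level. No measurement is at hand that would explain this reading.

Compound 1 differs from both in more than one place and so gives no gauge for this position. From the compounds shown here alone, whether a different group on the same carbonyl carbon, such as an aminophenyl, a methoxyphenyl or a phenyl carrying a carboxylic acid, would move the number beyond the scatter remains open.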